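A few compounds are considered here, and "the series" means these few. Any claim that something is new, unique, unknown or untested is made for them only; others in the source may bear on it.

Going by the values given here, compound 3 `CC(C)Cn1c(=O)n(C)c(=O)c2nc(CCCCCO)c(Cc3cccc4ccccc34)nc21` is the only member of this small set with a reported number: in an assay on MCF7 cells for inhibition of Monocarboxylate transporter 1 (Homo sapiens), read by scintillation counting, with a stated time of 10 min (a lower number here means a stronger inhibitor, a higher number a weaker inhibitor), compound 3 gives 192 nM. Its two companions carry the same core but different side chains and offer no comparison. Compound 1 `CC(C)Cn1c(=O)n(C)c(=O)c2nc(SCCO)c(Cc3cccc4ccccc34)nc21` is recorded in this assay as "not determined" (no result reported), and compound 2 `CC(C)Cn1c(=O)n(C)c(=O)c2nc(C(=O)NCCCO)c(Cc3cccc4ccccc34)nc21` likewise as "not determined" (no result reported). Among the compounds with values here, no pair of measured compounds differing in one place is therefore available, and compound 3 stands alone as the reference point.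

Compound 4 `CC(C)Cn1c(=O)n(C)c(=O)c2nc(/C=C\CCCO)c(Cc3cccc4ccccc34)nc21` departs from compound 3 by a single change, (5-hydroxypent-1-en-1-yl in place of 5-hydroxypentyl on an aromatic carbon), that is, 5-hydroxypent-1-en-1-yl in place of 5-hydroxypentyl on an aromatic carbon. The chain keeps its length and its hydroxyl; only one double bond is introduced. Within the data shown here, with no measured step to lean on, a change of this kind is expected to move the number little, if at all, and in no fixed direction. Compound 4 is therefore estimated at 200 nM, within a range from 80 nM to 500 nM, so that the expected step from a 1.0-fold higher number from compound 3 to compound 4 (0.02 log units; within the scatter) lies within the usual scatter.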

Compound 4, half-maximal inhibitory concentration: 116 nM
Compound 4: middle estimate off by 1.7-fold (0.24 log units), on the high side, within the range that was stated.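

In this assay, the place on the aromatic carbon ortho to a (naphthalen-1-yl)methyl group now has its first readable step: 5-hydroxypent-1-en-1-yl in place of 5-hydroxypentyl gives a 1.7-fold lower number from compound 3 to compound 4 (0.22 log units; within the scatter). At this position, then, adding a double bond to the chain while keeping its hydroxyl does not separate the two compounds beyond the usual variation between repeated measurements. No accompanying measurement bears on this result.

The compounds shown leave open whether the terminal hydroxyl is needed at all and how a shorter or longer chain, or a chain ending in a carboxylic acid or an amine, would read at this position. Steps involving compound 1 and compound 2 cannot be read, so their side chains offer no comparison with the chains of compound 3 and compound 4.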